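Working notes: compound 1 to compound 4 in the shared core

The compounds below may be only part of what the source reports. "The series", "measured", "known", "first", "only" and "open" are said of these compounds alone.

Measured so far in an assay on isolated protein for inhibition of Rho-associated protein kinase 1 (Homo sapiens), read by scintillation counting, radiometric assay and 33P incorporation, with a stated time of 40 min, in the presence of a further agent that is not named here; a lower number here means a stronger inhibitor, a higher number a weaker inhibitor:
- compound 1 `CCc1ccc(C(=O)Nc2cccc(NC(=O)COc3ccc4c(=O)ccoc4c3)c2)cc1` gives 235 nM
- compound 2 `CN(C)c1ccc(S(=O)(=O)Nc2cccc(NC(=O)COc3ccc4c(=O)ccoc4c3)c2)cc1` gives 803 nM
- compound 3 `O=C(COc1ccc2c(=O)ccoc2c1)Nc1cccc(NS(=O)(=O)c2ccc(OC(F)(F)F)cc2)c1` gives 6440 nM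

Compound 1 holds the lowest number of the three; compound 2 stands nearer, compound 3 furthest. For the measured compounds named here, the single one-place step measured, an 8.0-fold higher number from compound 2 to compound 3 (0.90 log units; beyond the scatter), concerns the sulfonamide pair and a different change, so it does not bear on the present step.

Compound 4 `NCc1ccc(C(=O)Nc2cccc(NC(=O)COc3ccc4c(=O)ccoc4c3)c2)cc1` differs from compound 1 by amino in place of methyl on a saturated chain carbon bound to an aromatic carbon. Going by the values given here, no measured step touches this part of the structure, so nothing here argues for a shift beyond the scatter in either direction. Compound 4 is therefore estimated near compound 1, at 180 nM (range 50 nM to 700 nM), the expected step being a 1.3-fold lower number from compound 1 to compound 4 (0.12 log units; within the scatter).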

Compound 4, half-maximal inhibitory concentration: 532 nM
Estimate against measurement, compound 4: 3.0-fold (0.47 log units) below; measured number inside the range.
By their numbers in this assay, from the lowest: compound 1; then compounds 4 and 2 (each within the scatter of the next); then compound 3.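

In this assay, for the compounds shown here, the first measured change at this position gives a 2.3-fold higher number from compound 1 to compound 4 (0.35 log units; beyond the scatter). Amino in place of methyl on a saturated chain carbon bound to an aromatic carbon therefore moves the number modestly upward, and 4-(aminomethyl)phenyl keeps compound 4 well short of the weakest value in the set, held by compound 3. No supporting measurement bears on this step, so the result stands without an account of its origin.

The compounds shown leave open whether a hydroxyl group or carboxylic acid on that chain carbon, or a longer chain ending in an amine, would give a lower number. They also leave open whether aminomethyl produces a similar step on the sulfonamide compounds.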